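This account rests on a few compounds, and the source may have more. Where it says the series, first, only, none or still open, it means among the compounds named here.

The study concerns three measured compounds and one still awaiting measurement in an assay on isolated protein for inhibition of Calpain-1 catalytic subunit (Homo sapiens), read by fluorescence, with a stated time of 60 min, tested at 1 uM; a lower number here means less inhibition, a higher number more inhibition at the concentration tested (going by the name of the read-out). Compound 3 `COCCN/C(=C1/N=C(C)N(CCOC)C1=O)c1cc2ccccc2[nH]1` stands highest of the three numbers, giving 93%. Compound 1 `COCCN/C(=C1/N=CN(CCOC)C1=O)c1cc2ccccc2[nH]1` gives 73.7%, and compound 2 `O=C1/C(=C(\NC2CCCCC2)c2cc3cccnc3[nH]2)N=CN1C1CCCCC1` gives 4.5%. For the measured compounds named here, the one single-point change measured so far is a number 19.3 percentage points higher from compound 1 to compound 3 (beyond the scatter), at the very carbon that is altered again here. Compound 4 `COCCN/C(=C1/N=C(c2ccccc2)N(CCOC)C1=O)c1cc2ccccc2[nH]1` differs from compound 3 by phenyl in place of methyl on a carbon with a double bond to nitrogen. Going by the values given here, no measured pair shows a phenyl replacing a methyl, so the size of this step cannot be read directly from the data, and compound 3 already sits near the top of the scale, leaving little room upward. Because a number 19.3 percentage points higher from compound 1 to compound 3 (beyond the scatter) was only modest, compound 4 is expected to move by about a number 8 percentage points lower from compound 3 to compound 4 (within the scatter), a step within or close to the scatter. The value of compound 4 is estimated at 85%, with a range from 60% to 98%.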

Compound 4, a percentage reported as inhibition, at one concentration (the size of the read-out at that concentration, not a potency): 21.5%
Estimate against measurement, compound 4: 63.5 percentage points above; measured number outside the range, below it.
By their numbers in this assay, from the lowest: compound 2; then compound 4; then compound 1; then compound 3.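

In this assay the number at the carbon with a double bond to nitrogen depends strongly on the group placed there: phenyl in place of methyl brings a number 71.5 percentage points lower from compound 3 to compound 4 (beyond the scatter) and phenyl in place of hydrogen brings a number 52.2 percentage points lower from compound 1 to compound 4 (beyond the scatter) at the same carbon. The earlier compounds shown here showed only a gain on going from hydrogen to methyl, whereas the three groups now show that the read-out does not rise steadily along hydrogen, methyl and phenyl, with phenyl falling beneath both of the others. Nothing available here accounts for this fall.

The compounds shown leave open how an ethyl group, a benzyl group or a cyclohexyl ring would read at this carbon, and so whether the loss belongs to phenyl alone. They also leave open whether a pyridine ring or an amine placed there would behave as phenyl does.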